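This account rests on a few compounds, and the source may have more. Where it says the series, first, only, none or still open, it means among the compounds named here.

Compounds measured so far in an assay on HEK293 cells for negative allosteric modulation of metabotropic glutamate receptor 5 (Homo sapiens), read by FLIPR, with a stated time of 1 h; on this read-out higher numbers stand for weaker inhibition and lower numbers for stronger inhibition:

Compound 1 `O=C1NCCc2nc(C#Cc3cccc(F)c3)sc21` — in this assay compound 1 gives > 10000 nM, which is a limit of the assay and not a number.
Compound 2 `Cc1cccc(C#Cc2nc3c(s2)C(=O)NCC3)c1` — in this assay compound 2 gives > 10000 nM, again a limit of the assay.
Compound 3 `CC(=O)N1CCc2nc(C#Cc3ccccc3)sc2C1` — in this assay compound 3 gives 90 nM.

Going by the values given here, compound 3 thus holds the only number in this assay; the other two values sit at the limit of > 10000 nM in this assay, at which 2 of the 3 values shown sit. Among the compounds with values here, the one measured step, a step that the two limits leave unreadable from compound 1 to compound 2, runs between two limits and cannot be read in size.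

Compound 4 `O=C(c1cccc(Cl)c1)N1CCc2nc(C#Cc3ccccc3)sc2C1` differs from compound 3 by 3-chlorophenyl in place of methyl on a carbonyl carbon. No measured step touches the carbonyl carbon, so nothing shown bears directly on this change; the unreadable step between compound 1 and compound 2 concerns a different part of the structure. With no guidance from the measured steps, the expectation for this assay is a step of no change at the digits printed from compound 3 to compound 4 (within the scatter), that is, none beyond the scatter, with a wide range to reflect the lack of any comparable step.

Compound 4 is therefore estimated at 90 nM in this assay, in the range 15 nM to 600 nM.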

Compound 4, half-maximal inhibitory concentration: > 10000 nM
Compound 4 was reported as a limit; the forecaster's own chance of this, stated with the estimate: 10%; middle value at least 110-fold (2.04 log units) away from the limit.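

In this assay, 3-chlorophenyl in place of methyl on a carbonyl carbon gives an at least 110-fold higher number from compound 3 to compound 4 (2.04 log units; beyond the scatter), the only readable step shown so far. The value of compound 4, > 10000 nM, is a limit of the assay and not a number, so the step has a lower bound but no known size. This carbonyl carbon is therefore the one place shown where a single change moves the read-out beyond the scatter, and compound 3 stays the only compound with a number: the limit of > 10000 nM in this assay, at which 3 of the 4 values shown sit.

Still open, going by these compounds, is whether the drop goes with the aromatic ring itself or with the chlorine, which an unsubstituted phenyl on this carbonyl carbon would separate. Also open, on these data alone, is how much room the position has for groups between these two extremes, such as ethyl, cyclopropyl or a dimethylamino group, in this assay.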